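The source may report more compounds than this note shows. Statements on the series, on what has been measured and on what is new or still open speak of the compounds shown alone.

For the measured compounds named here, compound 2 `COc1ccc(OC)c(C(=O)/C=C/c2ccc(C(=O)OCc3ccccc3)cc2)c1` gives the highest of the three numbers measured so far in a functional assay on PC-3 cells (Homo sapiens) for cytotoxicity, read by MTT assay, with a stated time of 72 h (a higher number here means a weaker inhibitor, a lower number a stronger inhibitor), with 18000 nM. Its nearest neighbour, compound 1 `CCOC(=O)c1ccc(/C=C/C(=O)c2cc(OC)ccc2OC)cc1`, gives 5700 nM in this assay, and the furthest, compound 3 `CNC(=O)c1ccc(/C=C/C(=O)c2cc(OC)ccc2OC)cc1`, gives 2130 nM. Compound 4 `COc1ccc(OC)c(C(=O)/C=C/c2ccc(C(=O)N3CCCC3)cc2)c1` differs from compound 2 in one place: pyrrolidin-1-yl in place of benzyloxy on a carbonyl carbon. Going by the values given here, two measured steps bear on this change. In the step of an 8.5-fold lower number from compound 2 to compound 3 (0.93 log units; beyond the scatter), benzyloxy also leaves the carbonyl carbon, and the number drops markedly. The step of a 3.2-fold higher number from compound 1 to compound 2 (0.50 log units; beyond the scatter) shows that the benzyloxy group, relative to ethoxy, goes with a higher number, so taking it away again is expected to lower the number. The step of a 2.7-fold lower number from compound 1 to compound 3 (0.43 log units; beyond the scatter) points the same way. The pyrrolidin-1-yl group carries no hydrogen-bond donor. The full size of the step of an 8.5-fold lower number from compound 2 to compound 3 (0.93 log units; beyond the scatter) is not assumed for compound 4. The expected step is a 5.1-fold lower number from compound 2 to compound 4 (0.71 log units; beyond the scatter) in this assay. Compound 4 is therefore estimated at 3500 nM, within a range from 1200 nM to 10000 nM.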

Compound 4, half-maximal inhibitory concentration: 530 nM
Estimate against measurement, compound 4: 6.6-fold (0.82 log units) above, and the stated range ends above it.
By their numbers in this assay, from the lowest: compound 4; then compound 3; then compound 1; then compound 2.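

Across the three new steps, the amides and esters at this carbonyl carbon separate further than the earlier compounds showed. In this assay, the change from an ester group is large in both cases, a 34-fold lower number from compound 2 to compound 4 (1.53 log units; beyond the scatter) and an 11-fold lower number from compound 1 to compound 4 (1.03 log units; beyond the scatter), so the low number is not tied to which ester group leaves. Pyrrolidin-1-yl, with 0 hydrogen-bond donors, also goes beyond methylamino, a 4.0-fold lower number from compound 3 to compound 4 (0.60 log units; beyond the scatter), so among these compounds the amide hydrogen of compound 3 is not needed for a low number, and compound 4 stands lowest of the four.

No measurement offered here explains why pyrrolidin-1-yl lowers the number this far. As far as these compounds go, how a dimethylamino or a morpholin-4-yl group on this carbonyl carbon would compare remains open, so it cannot be said whether the ring itself matters.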